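A few compounds are considered here, and "the series" means these few. Any claim that something is new, unique, unknown or untested is made for them only; others in the source may bear on it.

Measured so far:
compound 1 `N=C(NCCCc1c[nH]cn1)NC(=O)CC(c1ccccc1)c1ccccc1`, 28.2 nM
compound 2 `N=C(NCCCc1c[nH]cn1)NC(=O)CC(c1ccccc1)c1ccc(F)cc1`, 55 nM

In a functional assay on cardiac atrium for agonist activity at histamine H2 receptor (Cavia porcellus) (a lower number here means that less compound is needed, a higher number that more compound is needed for the effect), compound 1 gives 28.2 nM, and compound 2 gives 55 nM. Compound 2 thus holds the higher of the two numbers, but the step of a 2.0-fold higher number from compound 1 to compound 2 (0.29 log units; within the scatter) lies within the scatter, so no ranking of the two follows. Compound 3 `N=C(NCCCc1c[nH]cn1)NC(=O)CC(c1ccccc1)c1ccc(F)c(F)c1` carries the change (fluoro in place of hydrogen on an aromatic carbon). Among the compounds with values here, the only measured step bearing on it, a 2.0-fold higher number from compound 1 to compound 2 (0.29 log units; within the scatter), is the same kind of change and was small. A step of similar size, upward if anything, is therefore expected as a 1.5-fold higher number from compound 2 to compound 3 (0.16 log units; within the scatter). Compound 3 is estimated at 80 nM, in a range of 30 nM to 250 nM.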

Compound 3, half-maximal effective concentration: 53.7 nM
Estimate against measurement, compound 3: 1.5-fold (0.17 log units) above; the range from low to high includes it.
By their numbers in this assay, from the lowest: compounds 1, 3 and 2 (each within the scatter of the next).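

In this assay, fluoro in place of hydrogen ortho to the existing fluoro group gives a 1.0-fold lower number from compound 2 to compound 3 (0.01 log units; within the scatter), so a fluoro group at this place on the ring leaves the read-out within the scatter. The whole change from phenyl to 3,4-difluorophenyl gives a 1.9-fold higher number from compound 1 to compound 3 (0.28 log units; within the scatter), so the two fluoro groups together also show no readable effect. No measurement at hand explains this result. Going by these compounds, whether a methoxy group, a trifluoromethyl group or an amine at this place would leave the number unchanged stays open, as does fluoro on the other phenyl ring.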